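A few compounds are considered here, and "the series" means these few. Any claim that something is new, unique, unknown or untested is made for them only; others in the source may bear on it.

Measured compounds:
compound 1 `CCN(CC)c1c(C)n(CC)c(=O)n(-c2ccccc2)c1=O`: in a physicochemical assay for lipophilicity (a higher number here means a more lipophilic compound, a lower number a more polar compound), compound 1 gives 2.2
compound 2 `Nc1nc(N)nc(-c2ccccc2Br)n1`: compound 2 gives 1.26
compound 3 `Nc1nc(N)nc(-c2ccccc2[N+](=O)[O-])n1`: compound 3 gives 0.49

Compound 3 stands lowest of the three numbers. Its nearest neighbour is compound 2, which differs from it in one place only, and the step of a number 0.77 log units lower from compound 2 to compound 3 (beyond the scatter) is beyond the scatter. Compound 1 lies on a different core and is furthest from compound 3; nothing links the two beyond their values.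

Compound 4 `Nc1nc(N)nc(-c2ccccc2I)n1` is not yet measured. Compared with compound 3 the change is iodo in place of nitro on an aromatic carbon. Within the data shown here, the only measured step that bears on this change is the one from compound 2 to compound 3, in which nitro replaced bromo and the number fell by a number 0.77 log units lower from compound 2 to compound 3 (beyond the scatter). Compound 4 reverses the direction of that step, with a halogen again in place of nitro, though the entering halogen is iodo rather than bromo, so the measured step is a guide and not a match. A rise beyond the scatter is expected; compound 4 is estimated to sit around the value of compound 2, the expected step being a number 0.91 log units higher from compound 3 to compound 4 (beyond the scatter). The estimate for compound 4 is 1.4, with a range from 1 to 1.8.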

Compound 4, partition coefficient: 1.41
For compound 4 the middle estimate is 0.01 log units below the measured one; the measured number falls inside the stated range.
By their numbers in this assay, from the lowest: compound 3; then compounds 2 and 4 (each within the scatter of the next); then compound 1.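

In this assay, the step from nitro to iodo (a number 0.92 log units higher from compound 3 to compound 4 (beyond the scatter)) shows that the gap seen between bromo and nitro (a number 0.77 log units lower from compound 2 to compound 3 (beyond the scatter)) is not specific to bromo, since a second halogen on this aromatic carbon also stands clear of nitro. The two halogens are not separated from each other (a number 0.15 log units higher from compound 2 to compound 4 (within the scatter)), so exchanging bromo for iodo at this place leaves the read-out unresolved, while nitro stands alone among compound 2, compound 3 and compound 4 on the shared core. No measurement here gives a reason for this grouping of the three compounds.

Going by these compounds, it remains open whether other groups on this aromatic carbon, such as chloro, fluoro, methyl, an amine or a carboxylic acid, would fall with the two halogens, with nitro or somewhere else on the scale. On these data alone, it is also open whether the gap between nitro and the halogens would carry over to another place on the aromatic ring or to the core of compound 1, which offers no comparison with this set.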